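The compounds below may be only part of what the source reports. "The series", "measured", "known", "first", "only" and "open" are said of these compounds alone.

Compound 2 `c1ccc2c(c1)CCN2c1ccnc(Nc2ccc(Oc3ncnc4sccc34)cc2)n1` is recorded as "not active" (no number reported) in a functional assay on A549 cells (Homo sapiens) for inhibition, read by MTT assay, with a stated time of 72 h (on this read-out higher numbers stand for weaker inhibition and lower numbers for stronger inhibition), with no number attached, so there is no single value on which it can be placed; it cannot be ranked against anything. A second compound, compound 1 `CN(c1ccc(Oc2ncnc3sccc23)cc1)c1nccc(N2CCc3ccccc3C2)n1`, gives 6390 nM in this assay; it differs from compound 2 in more than one place, so only the two readings themselves can be set side by side. Compound 3 `CN(c1ccc(Oc2ncnc3sccc23)cc1)c1nccc(N2CCc3ccccc32)n1` arises from compound 2 by a single change: methyl in place of hydrogen on a nitrogen on an aromatic ring. Among the measured compounds shown here, no measured step covers this change. In this assay a modest move toward stronger inhibition is expected from compound 2 to compound 3, supported only by compound 1, which also carries a methyl on such a nitrogen and gives 6390 nM. Compound 3 is therefore estimated at 9000 nM in this assay, within a range from 3000 nM to 30000 nM, with a real chance that only a limit is reported.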

Compound 3, half-maximal inhibitory concentration: 19600 nM
Beside the measured number, compound 3's estimate is 2.2-fold (0.34 log units) below it; measured number inside the range.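

As far as these compounds go, with a methyl on the nitrogen, compound 3 gives 19600 nM in this assay while compound 2 has no number, so the step between them cannot be read and the size of the methyl change remains unknown. With that methyl present in both compounds, 2,3-dihydro-1H-indol-1-yl in place of 1,2,3,4-tetrahydroisoquinolin-2-yl on an aromatic carbon gives a 3.1-fold higher number from compound 1 to compound 3 (0.49 log units; beyond the scatter) and so a modest loss of inhibition, showing that this ring choice also affects the reading. No independent evidence explains either result.

The compounds shown leave open how an ethyl or a longer chain on this nitrogen would compare with methyl. They also do not show whether an open-chain amine on the aromatic carbon would give stronger or weaker inhibition than either ring.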